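Dropping a fluoro from compound 3: what to expect

The source may report more compounds than this note shows. Statements on the series, on what has been measured and on what is new or still open speak of the compounds shown alone.

Compound 1 `COc1ccc(N2C[C@@H](C)N[C@@H](C)C2)cc1NS(=O)(=O)c1ccc(-c2ccccn2)s1`: 10 nM
Compound 2 `COc1ccc(N2C[C@@H](C)N[C@@H](C)C2)cc1NS(=O)(=O)c1ccc(-c2ccccc2)cc1`: 6.31 nM
Compound 3 `COc1ccc(F)c(-c2ccc(S(=O)(=O)Nc3cc(N4C[C@@H](C)N[C@@H](C)C4)ccc3OC)cc2)c1`: 0.398 nM

In a functional assay for agonist activity at growth hormone secretagogue receptor type 1 (Homo sapiens), read by FLIPR (a lower number here means that less compound is needed, a higher number that more compound is needed for the effect), compound 3 gives the lowest of the three measured numbers; compound 2 and compound 1 both lie above it by more than the usual scatter.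

Compound 4 `COc1cccc(-c2ccc(S(=O)(=O)Nc3cc(N4C[C@@H](C)N[C@@H](C)C4)ccc3OC)cc2)c1` differs from compound 3 by hydrogen in place of fluoro on an aromatic carbon. For the measured compounds named here, the one measured step that bears on this is a 16-fold lower number from compound 2 to compound 3 (1.20 log units; beyond the scatter), but that step added the fluoro and the methoxy together; no measured step separates the fluoro alone. Compound 4 keeps the methoxy and loses the fluoro, so a number somewhere between those of compound 2 and compound 3 seems plausible. The expected step is therefore a modest rise, a 2.5-fold higher number from compound 3 to compound 4 (0.40 log units; beyond the scatter). Compound 4 is estimated at 1 nM, with a range from 0.4 nM to 3 nM.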

Compound 4, half-maximal effective concentration: 2 nM
For compound 4 the middle estimate is 2.0-fold (0.30 log units) below the measured one; the range from low to high includes it.
By their numbers in this assay, from the lowest: compound 3; then compound 4; then compounds 2 and 1 (each within the scatter of the next).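

The fluoro can now be read apart from the methoxy: taking it away alone gives a 5.0-fold higher number from compound 3 to compound 4 (0.70 log units; beyond the scatter) and shows that this single atom matters at this position. The methoxy matters as well, as a 3.2-fold lower number from compound 2 to compound 4 (0.50 log units; beyond the scatter) shows, so both groups contribute to the larger gain seen in a 16-fold lower number from compound 2 to compound 3 (1.20 log units; beyond the scatter) without either accounting for all of it. No measured evidence here explains why either group has this effect.

Whether the position needs fluorine in particular stays open, as the compounds shown carry only fluoro or hydrogen there. A chloro or a methyl at that spot would test this.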